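The source may hold more compounds than are shown below. What is called first, only, known or untested is meant among the compounds shown, and "the series" means these compounds.

In a functional assay on the whole organism with Rattus norvegicus as the target, at a dose of 20 mg/kg by the oral route (on this read-out higher numbers stand for more inhibition at the one dose given (going by the name of the read-out) and lower numbers for less inhibition), three closely related compounds have been measured. Compound 1 `CC(C)NC(=O)/C=C1\CCc2ccc(F)cc21` gives 45%, and compound 2 `CNC(=O)/C=C1\CCc2ccc(F)cc21` gives 45%; the step of no change at the digits printed from compound 1 to compound 2 (within the scatter) shows that trading the isopropyl for a methyl on the amide-type nitrogen leaves the read-out where it was. Compound 3 `CON(C)C(=O)/C=C1\CCc2ccc(F)cc21` gives 6%, the lowest of the three numbers: the step of a number 39 percentage points lower from compound 1 to compound 3 (beyond the scatter) and the step of a number 39 percentage points lower from compound 2 to compound 3 (beyond the scatter) are both large and beyond the scatter, so compound 3 stands clearly apart from the other two.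

Compound 4 `O=C(/C=C1\CCc2ccc(F)cc21)N1CCC1` has not yet been measured. Compared with compound 3 the change is azetidin-1-yl in place of methoxy(methyl)amino on a carbonyl carbon. Among the compounds with values here, the steps that bear on it are the two large drops into compound 3, which both accompany the arrival of the methoxy(methyl)amino group; compound 4 sheds that group again, but it also carries no amide hydrogen, a feature shared only with compound 3. Within the data shown here, no measured step separates these two aspects. A partial recovery is therefore expected, with the step of a number 19 percentage points higher from compound 3 to compound 4 (beyond the scatter) expected to be upward but uncertain. Compound 4 is estimated to give 25% in this assay, within a range from 5% to 50%.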

Compound 4, a percentage reported as inhibition, in the whole organism at one dose (the size of the read-out at that dose, not a potency): 14%
Beside the measured number, compound 4's estimate is 11 percentage points above it; measured number inside the range.
By their numbers in this assay, from the lowest: compounds 3 and 4 (each within the scatter of the next); then compounds 1 and 2 (each within the scatter of the next).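

Putting the azetidin-1-yl ring in place of the open methoxy(methyl)amino group on the carbonyl carbon gives a number 8 percentage points higher from compound 3 to compound 4 (within the scatter) in this assay and so the low level seen earlier does not depend on the methoxy(methyl)amino group alone: a group with as many heavy atoms, but with a ring and no oxygen, reads the same within the scatter. The amides that keep their hydrogen remain well apart, with a number 31 percentage points lower from compound 2 to compound 4 (beyond the scatter) and with a number 31 percentage points lower from compound 1 to compound 4 (beyond the scatter) placing compound 4 alongside compound 3 rather than alongside them. Across these four compounds, the two that carry the amide hydrogen read high and the two without it read low, and none goes against this split, although four compounds are a narrow basis for it.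

From the compounds shown here alone, it remains open whether a dimethylamino group, a larger ring such as piperidin-1-yl, or a plain amino group on the carbonyl carbon would follow the same split. Nothing at hand shows what lies behind the difference between these two pairs of compounds.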